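The source may report more compounds than this note shows. Statements on the series, on what has been measured and on what is new or still open speak of the compounds shown alone.

Within the data shown here, in a physicochemical assay for solubility, with a stated time of 4 h, at pH 7.4 (a higher number here means a more soluble compound, a lower number a less soluble compound), only two compounds have numbers so far. Compound 1 `CC(=O)CCc1cc(C)c(Oc2cc(Nc3ccc(C#N)cc3)c(N)cc2C(F)(F)F)c(C)c1` gives 0.16 ug/mL, and compound 2 `CNC(=O)c1cc(N)c(Nc2ccc(C#N)cc2)cc1Oc1c(C)cc(CCC#N)cc1C` gives 8.28 ug/mL. Compound 2 therefore holds the higher of the two numbers, and its gap to compound 1 lies beyond the scatter of the measurement.

Compound 3 `Cc1cc(CCC#N)cc(C)c1Oc1cc(Nc2ccc(C#N)cc2)c(N)cc1C(N)=O` differs from compound 2 in one place: hydrogen in place of methyl on an amide-type nitrogen. This puts hydrogen in place of methyl on an amide-type nitrogen, so methylcarbamoyl becomes carbamoyl.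

Among the measured compounds shown here, no measured pair of compounds differs in one place only, so the data do not yet show what a change of this kind does in this assay. The expectation therefore starts from compound 2 at 8.28 ug/mL and allows for a wide margin of doubt. A small downward shift is expected, one that may well stay within the scatter. The estimated change is a 1.5-fold lower number from compound 2 to compound 3 (0.18 log units; within the scatter). For compound 3, the expected value is 5.5 ug/mL, with an estimated range of 1.5 ug/mL to 20 ug/mL.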

Compound 3, solubility: 0.06 ug/mL
The estimate for compound 3 lay 92-fold (1.96 log units) above the measured number; the whole stated range lies above it.
By their numbers in this assay, from the lowest: compound 3; then compound 1; then compound 2.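

In this assay, compounds 2 and 3 form a pair that differs in one place only: taking the methyl off the amide-type nitrogen, so that methylcarbamoyl becomes carbamoyl, gives a 140-fold lower number from compound 2 to compound 3 (2.14 log units; beyond the scatter) and shows that this nitrogen is far from a silent place to make a change. Only one heavy atom leaves, a single carbon, with no ring and no net charge involved, so in this pair a very small change in structure goes with a very large step in the number. The data at hand offer no measurement that accounts for a step of this size.

From the compounds shown here alone, this single step gives a size at one place but no trend, so it remains open whether an ethyl group, a longer chain, or a chain ending in an amine or a carboxylic acid on this nitrogen would give a number near that of compound 2, near that of compound 3, or outside both. Going by these compounds, it also remains open whether the same swap of methyl for hydrogen gives a step of similar size when the rest of the molecule carries other groups.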